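The compounds below may be only part of what the source reports. "The series", "measured", "known", "first", "only" and "open" are said of these compounds alone.

- compound 1 `COc1cc(/C=C\c2ccsc2)cc(OC)c1OC`: "not determined" (no result reported)
- compound 2 `COc1cc(/C=C\c2cccs2)cc(OC)c1OC`: "not determined" (no result reported)
- compound 3 `COc1ccc(/C=C\c2cc(OC)c(OC)c(OC)c2)s1`: 76 nM

In a functional assay on IC8 cells (Homo sapiens) for antiproliferative activity, read by MTT assay, with a stated time of 72 h (a lower number here means a stronger inhibitor, a higher number a weaker inhibitor), compound 3 gives 76 nM. Going by the values given here, this is the only number available, so compound 3 cannot be ranked against anything. Compound 4 `COc1csc(/C=C\c2cc(OC)c(OC)c(OC)c2)c1` has the same atoms as compound 3, joined differently: 4-methoxythiophen-2-yl in place of 5-methoxythiophen-2-yl on a double-bonded chain carbon bound to a double-bonded chain carbon. It carries 4-methoxythiophen-2-yl in place of 5-methoxythiophen-2-yl on a double-bonded chain carbon bound to a double-bonded chain carbon. Among the compounds with values here, no pair of measured compounds shows the size of such a change, so this expectation is tentative. The expected change, a 3.3-fold higher number from compound 3 to compound 4 (0.52 log units; beyond the scatter), is estimated to be moderate and toward weaker inhibition. For compound 4 the estimated value is 250 nM, with an expected range from 50 nM to 1500 nM.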

Compound 4, half-maximal inhibitory concentration: 27 nM
Beside the measured number, compound 4's estimate is 9.3-fold (0.97 log units) above it, outside the stated range (below it).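

Placing 4-methoxythiophen-2-yl in place of 5-methoxythiophen-2-yl on a double-bonded chain carbon bound to a double-bonded chain carbon gives a 2.8-fold lower number from compound 3 to compound 4 (0.45 log units; beyond the scatter) in this assay, a modest step beyond the scatter. This shows that the result at this position depends on how the methoxy group is joined to the thiophene ring, even with the same atoms, which a single value could not show. Nothing available explains this difference. From the compounds shown here alone, what an ethoxy group or an amine in place of that methoxy group would do remains open.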